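Furan acid ethers: biaryl tail variation at the EP4 receptor

The source may hold more compounds than are shown below. What is called first, only, known or untested is meant among the compounds shown, and "the series" means these compounds.

Measured compounds:
compound 1 `CC(C)c1oc(C(=O)O)cc1COc1ccc(-c2ccccc2)cc1` — 3000 nM
compound 2 `Cc1oc(C(=O)O)cc1COc1ccc(-c2ccc(C#N)cc2)cc1` — 1500 nM

Two compounds of this series have been run in an assay on cells for displacement of a labelled ligand from prostaglandin E2 receptor EP4 subtype (Homo sapiens), read by scintillation counting; a higher number here means a weaker inhibitor, a lower number a stronger inhibitor. Compound 1 `CC(C)c1oc(C(=O)O)cc1COc1ccc(-c2ccccc2)cc1` gives 3000 nM. Compound 2 `Cc1oc(C(=O)O)cc1COc1ccc(-c2ccc(C#N)cc2)cc1` gives 1500 nM, the lower of the two numbers, though the gap to compound 1 lies within the scatter of repeated measurements, so the two cannot be ranked against each other.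

Compound 3 `COc1ccc(-c2ccc(OCc3cc(C(=O)O)oc3C)cc2)nc1` has not yet been measured. Compared with compound 2, it carries 5-methoxypyridin-2-yl in place of 4-cyanophenyl on an aromatic carbon. No step between measured compounds isolates this kind of exchange, so there is no shown precedent for its size or direction.

Among the compounds with values here, with only two numbers in hand and no comparable step, the expectation for compound 3 is a step of a 1.3-fold lower number from compound 2 to compound 3 (0.10 log units; within the scatter) that stays within the scatter rather than a clear shift in either direction. The estimate for compound 3 in this assay is 1200 nM, with a plausible range from 300 nM to 5000 nM.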

Compound 3, inhibition constant: 1300 nM
Beside the measured number, compound 3's estimate is 1.1-fold (0.03 log units) below it; measured number inside the range.
By their numbers in this assay, from the lowest: compounds 3, 2 and 1 (each within the scatter of the next, the first and the last beyond it).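

Within the data shown here, on an aromatic carbon of a six-membered aromatic ring of carbon only, para to a large group, putting 5-methoxypyridin-2-yl in place of 4-cyanophenyl gives in this assay a 1.2-fold lower number from compound 2 to compound 3 (0.06 log units; within the scatter), the first step that isolates a single place. At this position, then, the nitrile and the carbon-only terminal ring can both go without a shift that rises above the scatter, so for this pair the reading does not depend on either feature being present. No measurement on these compounds speaks to why the two groups read alike.

This single exchange alters the ring atoms and the substituent together, so the ring nitrogen and the methoxy group have no separate readings, and compound 1 differs from compound 2 and compound 3 in more than one place, which leaves the isopropyl and methyl groups on the shared core without a step of their own. As far as these compounds go, how a terminal ring carrying an amine or a carboxylic acid would read at this position also remains open.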